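The source may report more compounds than this note shows. Statements on the series, on what has been measured and on what is new or still open speak of the compounds shown alone.

Measured so far:
- compound 1, `CCN(Cc1cccnc1)c1ccc(C(=O)N2CCc3ccc(OS(N)(=O)=O)cc3C2)cc1`: 35.7%
- compound 2, `CCCN(CCC)c1ccc(C(=O)N2CCc3ccc(OS(N)(=O)=O)cc3C2)cc1`: 36.6%

Going by the values given here, in an assay on HEK293 cells for inhibition of Steryl-sulfatase (Homo sapiens), tested at 0.1 uM (on this read-out lower numbers stand for a weaker effect and higher numbers for a stronger effect at the one concentration tested), compound 2 gives 36.6%, and its only neighbour, compound 1, gives 35.7%; the two sit side by side, since the step of a number 0.9 percentage points higher from compound 1 to compound 2 (within the scatter) is no more than the assay's usual noise. Compound 3, `CCN(Cc1cccc(Br)c1)c1ccc(C(=O)N2CCc3ccc(OS(N)(=O)=O)cc3C2)cc1`, is the next compound: (3-bromobenzyl)(ethyl)amino in place of dipropylamino on an aromatic carbon. Among the compounds with values here, only one measured step bears on this change, namely a number 0.9 percentage points higher from compound 1 to compound 2 (within the scatter), and it shows that exchanging an ethyl((pyridin-3-yl)methyl)amino group for dipropylamino at this carbon left the read-out essentially unchanged. Compound 3 brings back an ethyl and an aromatic-ring-bearing arm on that same nitrogen, so on this evidence no step beyond the scatter is expected, a number 0.6 percentage points lower from compound 2 to compound 3 (within the scatter). Compound 3 is therefore estimated to give about 36%, with a likely range from 22% to 50%.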

Compound 3, a percentage reported as inhibition, at one concentration (the size of the read-out at that concentration, not a potency): 80.2%
Estimate against measurement, compound 3: 44.2 percentage points below; the measured number lies above the stated range.
By their numbers in this assay, from the lowest: compounds 1 and 2 (each within the scatter of the next); then compound 3.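

In this assay, the group on this aromatic carbon turns out to matter a great deal, something the closely matched compound 1 and compound 2 gave no sign of: (3-bromobenzyl)(ethyl)amino in place of dipropylamino gives a number 43.6 percentage points higher from compound 2 to compound 3 (beyond the scatter) on this read-out. The sharper comparison is 3-bromophenyl in place of pyridin-3-yl on the same arm, which gives a number 44.5 percentage points higher from compound 1 to compound 3 (beyond the scatter) and shows that having an aromatic ring on that arm is not enough, since the kind of ring makes the difference. No measurement here explains this jump.

The compounds shown leave open whether the bromine itself counts, as a plain benzyl or a 3-chlorobenzyl arm on the same nitrogen would test that. They also cannot say whether the ethyl group matters, or how a methyl or propyl group there would read.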